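The compounds below may be only part of what the source reports. "The series", "measured", "known", "first", "only" and "open" are said of these compounds alone.

In a functional assay on HepG2 cells (Homo sapiens) for cytotoxicity, read by MTT assay, with a stated time of 72 h (a higher number here means a weaker inhibitor, a lower number a stronger inhibitor), three compounds have been tested so far, and none of them gives an actual number. Compound 1 (`CN1CCN(c2ccc(Nc3ncc4nc(Nc5ccccc5)n(-c5ccccc5)c4n3)cc2)CC1`) reads > 5000 nM, which is a limit of the assay and not a measured value. Compound 2 (`OCCNc1ccc(Nc2ncc3nc(Nc4ccccc4)n(C4CCCC4)c3n2)cc1`) reads > 5000 nM, again a limit. Compound 3 (`CN1CCN(c2ccc(Nc3ncc4nc(Nc5cccc([N+](=O)[O-])c5)n(C5CCCC5)c4n3)cc2)CC1`) reads > 5000 nM, also a limit. It therefore stands with the other two, and the whole picture is the limit of > 5000 nM in this assay, at which 3 of the 3 values shown sit.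

Compound 4 (`Cc1cccc(Nc2nc3cnc(Nc4ccc(N5CCN(C)CC5)cc4)nc3n2C2CCCC2)c1`) has methyl in place of nitro on an aromatic carbon, meta to a large group, turning 3-nitrophenyl into 3-methylphenyl: methyl in place of nitro on an aromatic carbon. For the measured compounds named here, no two tested compounds differ in just one place, so no measured step is available as a guide. With compound 3 reading > 5000 nM, a limit, no step beyond the scatter is expected in this assay, in either direction. The expected change is a number no higher from compound 3 to compound 4 (the limit leaves the size open). A further limit is the most likely report. For compound 4 the estimated value is 5000 nM, with an expected range from 2500 nM to 10000 nM.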

Compound 4, half-maximal inhibitory concentration: 4700 nM
For compound 4 the middle estimate is 1.1-fold (0.03 log units) above the measured one, and the stated range covers the measured number.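

For the compounds shown here, with methyl in place of nitro on an aromatic carbon, meta to a large group, compound 4 gives 4700 nM in this assay, the first actual number. The other compounds all stay at a limit: the limit of > 5000 nM in this assay, at which 3 of the 4 values shown sit.

Compound 3 reads > 5000 nM, which is a limit of the assay. From the compounds shown here alone, the change is an at least 1.0-fold lower number from compound 3 to compound 4 (0.02 log units; that floor lies within the scatter), so going from 3-nitrophenyl to 3-methylphenyl brings a readable value into the assay, but the true size of the change stays unknown and may be small.

The compounds shown leave open how an amine, a carboxylic acid or a longer chain would read in this same position. Going by these compounds alone, with only one measured number, no trend across the series can yet be stated.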